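Swapping Nitro for Methyl in a Growth Inhibitor

The compounds below may be only part of what the source reports. "The series", "measured", "known", "first", "only" and "open" are said of these compounds alone.

In a functional assay on U-251 cells (Homo sapiens) for inhibition, read by MTT assay, with a stated time of 2 days (a higher number here means a weaker inhibitor of growth, a lower number a stronger inhibitor of growth), compound 1 `Nc1ccccc1NC(=O)c1ccc(NCC(=O)Nc2ccc([N+](=O)[O-])cc2)cc1` gives 42500 nM. Going by the values given here, that is the only true number available in this small set of compounds. Compound 2 `Nc1ccccc1NC(=O)CCCNCC(=O)Nc1cc(Cl)ccc1Cl` gives > 100000 nM, which is a limit of the assay and not a number. Compound 3 `Nc1ccccc1NC(=O)CCCNCC(=O)Nc1ccccc1Cl` gives > 100000 nM, which is also a limit of the assay and not a number.

Compound 4 `Cc1ccc(NC(=O)CNc2ccc(C(=O)Nc3ccccc3N)cc2)cc1` has not yet been measured. It differs from compound 1 in a single place: methyl in place of nitro on an aromatic carbon. In words, this is methyl in place of nitro on an aromatic carbon, para to a large group. The rest of the structure stays the same, so compound 1 is the natural starting point for an estimate.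

Among the compounds with values here, the one measured step, a step that the two limits leave unreadable from compound 2 to compound 3, concerns a different change, and its size cannot be read. It therefore offers no size or direction to carry over. No measurement here speaks to nitro or methyl, so the expectation is for no shift beyond the usual scatter in this assay. The expected step is a 1.1-fold higher number from compound 1 to compound 4 (0.02 log units; within the scatter). For compound 4 the estimated value is 45000 nM, with an expected range from 18000 nM to 100000 nM.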

Compound 4, concentration for total growth inhibition: > 100000 nM
Compound 4: only a limit was reported (the forecaster's own chance of this, stated with the estimate: 25%); middle value at least 2.2-fold (0.34 log units) away from the limit.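

In this assay the swap of nitro for methyl on an aromatic carbon, para to a large group, gives an at least 2.3-fold higher number from compound 1 to compound 4 (0.37 log units; beyond the scatter) and so shows that this position is not indifferent to what it carries. Going by these compounds alone, nothing earlier could show this, as the only other step in the set, between the two chlorinated compounds, cannot be read, and that step concerns a different change on a different chain. As far as these compounds go, the true size of the new step stays unknown, as the value of compound 4 is a limit of the assay and not a number, and that same ceiling hides much of this small set: the limit of > 100000 nM in this assay, at which 3 of the 4 values shown sit.

From the compounds shown here alone, with only nitro and methyl compared here, it remains open whether nitro is special or whether methyl is simply a poor fit at this spot, and an amine or a carboxylic acid on the same carbon of the core of compound 1 would help to tell these apart. Going by these compounds, it also remains open whether the same swap would matter on the butanamide-type chain of the chlorinated compounds, whose values give no number to start from.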